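A new aromatic group on the amine nitrogen

The source may report more compounds than this note shows. Statements on the series, on what has been measured and on what is new or still open speak of the compounds shown alone.

Of the compounds shown here, three sharing one core have been measured in a physicochemical assay for lipophilicity; a lower number here means a more polar compound, a higher number a more lipophilic compound. Compound 1 `COc1ccc(CN(CCN(C)C)c2ccc(Cl)cc2)cc1`, the chloro member, gives 4.47. Compound 3 `COc1ccc(CN(CCN(C)C)c2ccc(C)cc2)cc1`, the methyl member, gives 4.43, and the two cannot be told apart on this measurement: a number 0.04 log units lower from compound 1 to compound 3 (within the scatter). Compound 2 `COc1ccc(CN(CCN(C)C)c2ccc(N)cc2)cc1`, the amino member, gives 3.13, and the gap to the methyl member is large: a number 1.30 log units higher from compound 2 to compound 3 (beyond the scatter).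

Compound 4 `COc1ccc(CN(CCN(C)C)c2ccc(Cl)cn2)cc1` has not yet been measured. Its difference is 5-chloropyridin-2-yl in place of 4-methylphenyl on an amine nitrogen. Two things therefore change at once. For the exchange of methyl and chloro, the relevant measured step is small, a number 0.04 log units lower from compound 1 to compound 3 (within the scatter), so that part alone points to no shift. The step of a number 1.34 log units lower from compound 1 to compound 2 (beyond the scatter) shows that this series can move a long way on one aromatic exchange, but amino is not involved here. Among the measured compounds shown here, no measured compound has a hetero atom in this ring, so that part of the change is untested, and the expectation rests on the structural change alone.

A clear downward move is expected in this assay. The expected step is a number 0.83 log units lower from compound 3 to compound 4 (beyond the scatter). Compound 4 is estimated at 3.6, with an expected range from 3.1 to 4.1.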

Compound 4, partition coefficient: 3.87
Beside the measured number, compound 4's estimate is 0.27 log units below it; the measured number falls inside the stated range.
By their numbers in this assay, from the lowest: compound 2; then compound 4; then compounds 3 and 1 (each within the scatter of the next).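

Among the compounds shown here, compound 4 shows that a hetero atom in the aromatic group on the amine nitrogen can shift the number in this assay, something no earlier compound could test. The cleanest reading comes with chlorine retained, where 5-chloropyridin-2-yl replaces 4-chlorophenyl: a number 0.60 log units lower from compound 1 to compound 4 (beyond the scatter). The step from the methyl member is of similar size, a number 0.56 log units lower from compound 3 to compound 4 (beyond the scatter), while a number 0.74 log units higher from compound 2 to compound 4 (beyond the scatter) shows that this change does not bring the number down as far as the 4-aminophenyl group does.

Nothing among the data shown accounts for the drop seen with this ring. Going by these compounds, it also remains open whether a 5-methylpyridin-2-yl or 5-aminopyridin-2-yl group on the same amine nitrogen would give a step of similar size, so the shift seen here is established only for the chloro-bearing ring of compound 4.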